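Swapping the Amide Ring: From Compound 3 to Compound 4

This account rests on a few compounds, and the source may have more. Where it says the series, first, only, none or still open, it means among the compounds named here.

Of the compounds shown here, three sharing one core have been tested in an assay on isolated protein for inhibition of aldehyde dehydrogenase 1A1 (Homo sapiens), read by spectrophotometry, tested at 10 uM; on this read-out higher numbers stand for more inhibition at the one concentration tested (going by the name of the read-out) and lower numbers for less inhibition. Compound 1 `CC(C)=CCn1c(CN2CCN(C(=O)C3CC3)CC2)nc2ccccc21` gives 74.3%. Going by the values given here, compound 2 `CCn1c(CN2CCN(C(=O)C3CC3)CC2)nc2ccccc21` gives 20.8%, and the step of a number 53.5 percentage points lower from compound 1 to compound 2 (beyond the scatter) is the only single-place change measured so far. Compound 3 `Cc1cccc(Cn2c(CN3CCN(C(=O)c4cccnc4)CC3)nc3ccccc32)c1` gives 24.5%, the second highest of the three numbers; this value lies within the scatter of compound 2 and beyond the scatter below compound 1.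

Compound 4 `Cc1cccc(Cn2c(CN3CCN(C(=O)c4cccs4)CC3)nc3ccccc32)c1` differs from compound 3 in one place: thiophen-2-yl in place of pyridin-3-yl on a carbonyl carbon. Among the compounds with values here, no measured step touches the ring on this carbonyl carbon; the one measured step concerns the chain on the aromatic nitrogen at the other end of the core, so the data give no direction for this change. The expected step is therefore a number 0.5 percentage points higher from compound 3 to compound 4 (within the scatter), nothing beyond the scatter. Because compound 3 gives 24.5%, compound 4 is estimated at 25% in this assay, with a range from 10% to 45%.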

Compound 4, a percentage reported as inhibition, at one concentration (the size of the read-out at that concentration, not a potency): 60.8%
Compound 4: middle estimate off by 35.8 percentage points, on the low side; the whole stated range lies below it.
By their numbers in this assay, from the lowest: compounds 2 and 3 (each within the scatter of the next); then compound 4; then compound 1.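

In this assay, the ring on the carbonyl carbon proves to be a place that strongly moves the number, with thiophen-2-yl in place of pyridin-3-yl giving a number 36.3 percentage points higher from compound 3 to compound 4 (beyond the scatter) in a single change. Going by these compounds alone, the earlier step concerned only the chain on the aromatic nitrogen, so this is the first sign that the other end of the shared core counts as well. The change replaces a six-membered aromatic ring holding nitrogen with a five-membered one holding sulfur, and nothing available explains why the number rises.

These two compounds cannot separate the effect of ring size from that of the hetero atom, a question that phenyl or furan-2-yl on the same carbonyl carbon could address. As far as these compounds go, it also remains open whether the step holds with another chain on the aromatic nitrogen.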